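Thiophen-2-yl for 4-methylphenyl in an acylguanidine series

The source may report more compounds than this note shows. Statements on the series, on what has been measured and on what is new or still open speak of the compounds shown alone.

Of the compounds shown here, three of a shared core have been measured in an assay on membranes from Sf9 cells for displacement of a labelled ligand from histamine H2 receptor (Homo sapiens), read by scintillation counting, with a stated time of 60 min; a higher number here means a weaker inhibitor, a lower number a stronger inhibitor. Compound 1 `Cc1nc(N)sc1CCCN/C(N)=N/C(=O)N[C@H](C)c1ccccc1` gives 17.8 nM, compound 2 `CCCNC(=O)/N=C(\N)NCCCc1sc(N)nc1C` gives 105 nM, and compound 3 `Cc1ccc(C(C)NC(=O)/N=C(\N)NCCCc2sc(N)nc2C)cc1` gives 30.9 nM. Going by the values given here, the only single-point step is a 5.9-fold higher number from compound 1 to compound 2 (0.77 log units; beyond the scatter). Compound 3 stands second highest of the three numbers; its gap to compound 1 lies within the scatter, its gap to compound 2 beyond it. Compound 4 `Cc1nc(N)sc1CCCN/C(N)=N/C(=O)NC(C)c1cccs1` differs from compound 3 by thiophen-2-yl in place of 4-methylphenyl on a saturated chain carbon bound to an amide-type nitrogen and a saturated chain carbon. Among the compounds with values here, no measured step swaps one ring for another at this carbon, so the expectation rests on compound 1 and compound 3 alone, whose values sit close together. The step is therefore estimated as a 1.4-fold lower number from compound 3 to compound 4 (0.15 log units; within the scatter), and compound 4 is expected to give 22 nM, between 8 nM and 60 nM.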

Compound 4, inhibition constant: 63.1 nM
The estimate for compound 4 lay 2.9-fold (0.46 log units) below the measured number; measured number above the stated range.
By their numbers in this assay, from the lowest: compounds 1 and 3 (each within the scatter of the next); then compounds 4 and 2 (each within the scatter of the next).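

In this assay the ring on this carbon counts: thiophen-2-yl in place of 4-methylphenyl gives a loss beyond the scatter (a 2.0-fold higher number from compound 3 to compound 4 (0.31 log units; beyond the scatter)), and 1-(thiophen-2-yl)ethyl in place of 1-phenylethyl gives a larger one (a 3.5-fold higher number from compound 1 to compound 4 (0.55 log units; beyond the scatter)). Set against propyl, 1-(thiophen-2-yl)ethyl stays within the scatter (a 1.7-fold lower number from compound 2 to compound 4 (0.22 log units; within the scatter)), so this ring shows no clear gain over the open chain. No measured evidence accounts for this result. The compounds shown leave open whether furan-2-yl or pyridin-2-yl on this carbon would track thiophen-2-yl or 4-methylphenyl.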